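The compounds below may be only part of what the source reports. "The series", "measured", "known", "first", "only" and "open" are said of these compounds alone.

In an assay on CHO cells for antagonist activity at transient receptor potential cation channel subfamily V member 1 (Homo sapiens), read by FLIPR and calcium flux (a higher number here means a weaker inhibitor, a lower number a stronger inhibitor), the measured compounds stand as follows:

Compound 1 `CC(C(=O)NCc1ccc(C(F)(F)F)nc1Br)c1ccc(NS(C)(=O)=O)c(F)c1` gives 169 nM.
Compound 2 `CCCCCc1nc(C(F)(F)F)ccc1CNC(=O)C(C)c1ccc(NS(C)(=O)=O)c(F)c1` gives 1 nM.
Compound 3 `CC(C(=O)NCc1ccc(C(F)(F)F)nc1C1CCC(C)(C)CC1)c1ccc(NS(C)(=O)=O)c(F)c1` gives 0.4 nM.

Compound 1 has the highest number of the three. Replacing its bromo group with pentyl gives a 170-fold lower number from compound 1 to compound 2 (2.23 log units; beyond the scatter), and replacing it with 4,4-dimethylcyclohexyl gives a 420-fold lower number from compound 1 to compound 3 (2.63 log units; beyond the scatter); the two replacements themselves are separated by a 2.5-fold lower number from compound 2 to compound 3 (0.40 log units; beyond the scatter).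

Compound 4 `CCC1CC=C(c2nc(C(F)(F)F)ccc2CNC(=O)C(C)c2ccc(NS(C)(=O)=O)c(F)c2)CC1` differs from compound 1 in one place: 4-ethylcyclohex-1-en-1-yl in place of bromo on an aromatic carbon. Both changes at the same aromatic carbon gave large drops in this assay, so a large drop of similar size is expected here, namely a 280-fold lower number from compound 1 to compound 4 (2.45 log units; beyond the scatter). Compound 4 is therefore estimated at 0.6 nM, with a range from 0.2 nM to 3 nM.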

Compound 4, inhibition constant: 0.1 nM
The estimate for compound 4 lay 6.0-fold (0.78 log units) above the measured number; measured number below the stated range.
By their numbers in this assay, from the lowest: compound 4; then compound 3; then compound 2; then compound 1.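

In this assay, the 4-ethylcyclohex-1-en-1-yl group on this aromatic carbon next to the ring nitrogen goes further than either earlier replacement of bromo, with a 1700-fold lower number from compound 1 to compound 4 (3.23 log units; beyond the scatter), alongside a 4.0-fold lower number from compound 3 to compound 4 (0.60 log units; beyond the scatter) and a 10-fold lower number from compound 2 to compound 4 (1.00 log units; beyond the scatter). The number at this position therefore had not reached its floor with the pentyl chain or the 4,4-dimethylcyclohexyl ring. No evidence at hand accounts for this gain.

The ring substitution and the double bond both differ between compound 3 and compound 4, so their shares remain unseparated. On these data alone, whether a piperidine ring or a phenyl ring at this carbon would match compound 4 stays open.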